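The source may hold more compounds than are shown below. What is called first, only, known or untested is meant among the compounds shown, and "the series" means these compounds.

Working notes on the series. In a functional assay on HCT-116 cells (Homo sapiens) for inhibition, read by CCK-8 assay, with a stated time of 48 h (on this read-out lower numbers stand for stronger inhibition and higher numbers for weaker inhibition), compound 1 (`COc1cc(-c2ccnc3cc(-c4ccccc4)nn23)cc(OC)c1OC`) gives 3880 nM, compound 2 (`COc1cc(-c2ccnc3cc(-c4ccc5c(ccn5C)c4)nn23)cc(OC)c1OC`) gives 39 nM and compound 3 (`C=Cc1ccc(-c2cc3nccc(-c4cc(OC)c(OC)c(OC)c4)n3n2)cc1`) gives 1060 nM. Compound 3 therefore holds the second highest of the three numbers, with compound 2 the strongest so far.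

The next case is compound 4 (`COc1cc(-c2ccnc3cc(-c4ccc5cnn(C)c5c4)nn23)cc(OC)c1OC`). The change is 1-methyl-1H-indazol-6-yl in place of 4-vinylphenyl on an aromatic carbon: 1-methyl-1H-indazol-6-yl in place of 4-vinylphenyl, on an aromatic carbon of a five-membered aromatic ring with 2 nitrogen.

Going by the values given here, three measured steps bear on this. The large 99-fold lower number from compound 1 to compound 2 (2.00 log units; beyond the scatter) came with 1-methyl-1H-indol-5-yl in place of phenyl. The modest 3.7-fold lower number from compound 1 to compound 3 (0.56 log units; beyond the scatter) came with vinyl in place of hydrogen. The large 27-fold higher number from compound 2 to compound 3 (1.43 log units; beyond the scatter) compares the leaving group directly with 1-methyl-1H-indol-5-yl.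

The entering group resembles that group of compound 2, but it carries a second ring nitrogen and a different point of attachment. Among the compounds with values here, no measured compound tests either difference, so only part of the gain is assumed to carry over.

In this assay, a sizeable move to a lower number is expected, with an 8.8-fold lower number from compound 3 to compound 4 (0.95 log units; beyond the scatter) as the estimated step. Compound 4 is estimated at 120 nM, with an expected range of 25 nM to 600 nM.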

Compound 4, half-maximal inhibitory concentration: 2440 nM
Beside the measured number, compound 4's estimate is 20-fold (1.31 log units) below it, and the stated range ends below it.
By their numbers in this assay, from the lowest: compound 2; then compound 3; then compounds 4 and 1 (each within the scatter of the next).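

In this assay, the gain seen with 1-methyl-1H-indol-5-yl at this position does not extend to 1-methyl-1H-indazol-6-yl: exchanging one group for the other gives a 63-fold higher number from compound 2 to compound 4 (1.80 log units; beyond the scatter), so a five-membered aromatic ring joined to the six-membered aromatic ring does not by itself preserve the low number of compound 2. Against the plain phenyl group, 1-methyl-1H-indazol-6-yl gives a 1.6-fold lower number from compound 1 to compound 4 (0.20 log units; within the scatter), while replacing 4-vinylphenyl with it gives a 2.3-fold higher number from compound 3 to compound 4 (0.36 log units; beyond the scatter), which places this larger entering group on the weaker side of the 4-vinylphenyl group. No supporting measurement is available to explain these steps.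

The compounds shown leave open whether the second ring nitrogen or the different point of attachment accounts for the step between the indole and indazole groups, since the two differences occur together; 1-methyl-1H-indazol-5-yl and 1-methyl-1H-indol-6-yl would separate them. Also open, from the compounds shown here alone, is how far the effect of the 4-vinylphenyl group extends to a 4-ethylphenyl or 4-aminophenyl group at this position.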